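Moving a Hydroxyl Group Around the Ring

This account rests on a few compounds, and the source may have more. Where it says the series, first, only, none or still open, it means among the compounds named here.

Of the compounds shown here, two built on one shared core have been tested in a functional assay on HepG2 cells (Homo sapiens) for inhibition, read by MTT assay, with a stated time of 48 h; a lower number here means a stronger inhibitor, a higher number a weaker inhibitor. Compound 1, `Clc1ccc(CSc2nnc(-c3ccncc3)n2-c2ccccc2)cc1`, gives 16900 nM in this assay. Compound 2, `O=C(CSc1nnc(-c2ccncc2)n1-c1ccccc1)N/N=C/c1ccc(O)cc1`, carries a longer side chain that ends in a 4-hydroxyphenyl. For compound 2 the measurement stops at a limit of this assay, > 50000 nM, rather than a number. Compound 2 therefore stands at the limit of > 50000 nM in this assay, at which 1 of the 2 values shown sits, which places it among the weaker inhibitors without telling exactly how weak.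

Compound 3, `O=C(CSc1nnc(-c2ccncc2)n1-c1ccccc1)N/N=C/c1ccccc1O`, is the next compound to be measured. It is made of the same atoms as compound 2, joined differently: 2-hydroxyphenyl in place of 4-hydroxyphenyl on a carbon with a double bond to nitrogen. Among the compounds with values here, no measured pair in this set shows what such a move of the hydroxyl group does, so the expectation rests on compound 2 alone. Since compound 2 sits at a limit, the step from compound 2 to compound 3 is expected to be no larger than the usual scatter, a step that the limit leaves unreadable from compound 2 to compound 3. Compound 3 is therefore estimated at 60000 nM in this assay, with a likely range from 20000 nM to 180000 nM.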

Compound 3, half-maximal inhibitory concentration: 11300 nM
Beside the measured number, compound 3's estimate is 5.3-fold (0.73 log units) above it, outside the stated range (below it).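

Within the data shown here, this is the first pair in the set to isolate where the hydroxyl group sits on the ring, and in this assay the move gives an at least 4.4-fold lower number from compound 2 to compound 3 (0.64 log units; beyond the scatter). The two compounds differ only in having 2-hydroxyphenyl in place of 4-hydroxyphenyl, with the same atoms and the same counts of hydrogen-bond donors and acceptors, so relocating this one group on the carbon with a double bond to nitrogen is enough to change the result beyond the usual scatter. The step can only be given as a minimum, since compound 2 stands at a limit rather than at a number: the limit of > 50000 nM in this assay, at which 1 of the 3 values shown sits.

The data show that the hydroxyl group's location matters in this one pair, but not why it matters or whether a hydroxyl group is needed at all. A plain phenyl, 3-hydroxyphenyl, 2-methoxyphenyl or 2-aminophenyl at the same place would be needed to tell whether the hydroxyl group itself or simply a group at that ring position goes with the stronger inhibition.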